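A Second Methoxy on Compound 3

A few compounds are considered here, and "the series" means these few. Any claim that something is new, unique, unknown or untested is made for them only; others in the source may bear on it.

Measured in a functional assay on AGS cells (Homo sapiens) for antiproliferative activity, read by MTT assay, with a stated time of 48 h; on this read-out lower numbers stand for stronger inhibition of growth and higher numbers for weaker inhibition of growth:
Compound 1 `COc1ccc(N(C)c2ncnc3[nH]cnc23)cc1`: > 100000 nM (a limit)
Compound 2 `COc1ccc(N(C)c2ncnc3c2ncn3Cc2ccc(OC)c(OC)c2)cc1`: > 100000 nM (a limit)
Compound 3 `COc1ccc(Cn2cnc3c(Cl)ncnc32)cc1`: 29000 nM

Only one of these three results is an actual number. Compound 1 gives > 100000 nM, which is a limit of the assay. Compound 2 gives > 100000 nM, which is also a limit. Going by the values given here, compound 3 gives 29000 nM in this assay, and it is the only compound here with a number.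

The next compound is compound 4 `COc1ccc(Cn2cnc3c(Cl)ncnc32)cc1OC`. It is compound 3 with one change, methoxy in place of hydrogen on an aromatic carbon.

Among the compounds with values here, no two measured compounds differ in just one place, so no measured step speaks directly to this change. The closest reference is compound 3 at 29000 nM, and the expectation starts from that value, with no clear direction of change. The expected shift is a 1.2-fold lower number from compound 3 to compound 4 (0.06 log units; within the scatter), which is estimated to stay within the usual scatter of this assay. A result reported only as a limit also remains possible. For compound 4 the expected value is 25000 nM, with an estimated range from 8000 nM to 80000 nM.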

Compound 4, concentration for 50% growth inhibition: > 100000 nM
Compound 4: only a limit was reported; the forecaster's own chance of this, stated with the estimate: 20%; at least 4.0-fold (0.60 log units) between middle value and limit.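

In this assay, a methoxy in place of hydrogen on the aromatic carbon ortho to a methoxy group and meta to a large group gives the first readable step among these compounds, an at least 3.4-fold higher number from compound 3 to compound 4 (0.53 log units; beyond the scatter). The change is therefore not neutral at this position: it takes the series' only measured number up to the limit of the assay, so compound 4 offers no value of its own, and the step fixes only a minimum for the loss of growth inhibition, not its true size. Compound 3 now stands alone as the one compound with a real number, and everything else sits at the same ceiling: the limit of > 100000 nM in this assay, at which 3 of the 4 values shown sit.

The step that links compound 2 with compound 4 cannot be read, since both of its ends are limits. On these data alone, it also remains open whether this loss belongs to methoxy in particular or to substitution at this carbon in general, a question that a fluoro, a hydroxy or an ethoxy group on the same carbon would begin to answer.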